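The source may hold more compounds than are shown below. What is called first, only, known or untested is meant among the compounds shown, and "the series" means these compounds.

In an ADME assay on J774 cells (Mus musculus) for cytotoxicity (on this read-out lower numbers stand for an effect already at smaller amounts and higher numbers for an effect only at larger amounts of compound), compound 1 `COC(=O)c1c[nH]c2cc(OCc3ccccc3)ccc2c1=O` gives 18900 nM and compound 2 `COC(=O)c1c[nH]c2cc(OCCc3ccccc3)ccc2c1=O` gives 17200 nM, so compound 2 stands level with compound 1, as a 1.1-fold lower number from compound 1 to compound 2 (0.04 log units; within the scatter) lies within the scatter. Compound 3 `COC(=O)c1c[nH]c2cc(Oc3ccccc3)ccc2c1=O` has phenyl in place of phenethyl on an oxygen on an aromatic ring. Among the measured compounds shown here, that one measured step also changed the group on this oxygen, but no measured compound yet has phenyl there, so the guide is limited. The expected change in this assay is none beyond the scatter, an estimated 1.0-fold higher number from compound 2 to compound 3 (0.02 log units; within the scatter). Compound 3 is estimated at 18000 nM, with an expected range of 8000 nM to 40000 nM.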

Compound 3, half-maximal effective concentration: 9120 nM
The estimate for compound 3 lay 2.0-fold (0.30 log units) above the measured number, and the stated range covers the measured number.
By their numbers in this assay, from the lowest: compounds 3, 2 and 1 (each within the scatter of the next, the first and the last beyond it).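

Phenyl on this oxygen gives the first step beyond the scatter in this assay, with a 2.1-fold lower number from compound 1 to compound 3 (0.32 log units; beyond the scatter), though the shift is modest. The same change set against phenethyl stays within the scatter, with a 1.9-fold lower number from compound 2 to compound 3 (0.28 log units; within the scatter), so only the comparison with benzyl separates two of these compounds. Nothing available explains this shift. The compounds shown carry only an unsubstituted carbon ring on this oxygen. As far as these compounds go, how this read-out would respond to an amine or a carboxylic acid on the chain remains open.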